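Swapping the Group on an Amide-Type Nitrogen

The source may report more compounds than this note shows. Statements on the series, on what has been measured and on what is new or still open speak of the compounds shown alone.

Compound 1 `COC(=O)c1cc(=O)c2cc(NC(=O)Nc3cccc(C(C)=O)c3)ccc2[nH]1`: > 8080 nM
Compound 2 `COC(=O)c1cc(=O)c2cc(NC(=O)NCc3ccccc3)ccc2[nH]1`: > 19500 nM

Both compounds share a core and differ only in the group on an amide-type nitrogen. In a functional assay on HepG2 cells (Homo sapiens) for antiproliferative activity, with a stated time of 72 h (a higher number here means that more compound is needed for the effect, a lower number that less compound is needed), compound 1 reaches only the limit of the test, > 8080 nM. In this assay compound 2 also reaches only a limit, > 19500 nM. The step that the two limits leave unreadable from compound 1 to compound 2 therefore cannot be read. Because the limit of > 19500 nM in this assay, at which 1 of the 2 values shown sits, is a limit, compound 2 has no measured number. Because the limit of > 8080 nM in this assay, at which 1 of the 2 values shown sits, is a limit, the same holds for compound 1. Compound 2 thus stands at a limit and nowhere else.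

Compound 3 `COC(=O)c1cc(=O)c2cc(NC(=O)Nc3ccc4c(c3)CCC4)ccc2[nH]1` carries the change (2,3-dihydro-1H-inden-5-yl in place of benzyl on an amide-type nitrogen). No readable measured step bears on this change; the only step shown is unreadable. With both neighbours sitting at limits, compound 3 is expected to give 15000 nM, within a range from 3000 nM to 60000 nM. The step of an at least 1.3-fold lower number from compound 2 to compound 3 (0.11 log units; that floor lies within the scatter) is likewise only an expectation, most likely ending in another limit.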

Compound 3, half-maximal effective concentration: > 24100 nM
Compound 3: no number, only a limit; the forecaster's own chance of this, stated with the estimate: 70%; at least 1.6-fold (0.20 log units) between middle value and limit.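

In this assay compound 3 reaches only a limit, > 24100 nM. The steps to compound 3 from compound 1 and from compound 2 cannot be read. The compounds shown leave open which group on the amide-type nitrogen, if any, would give a measured number in this assay.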